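The source may hold more compounds than are shown below. What is called first, only, known or untested is meant among the compounds shown, and "the series" means these compounds.

Going by the values given here, in an in vivo ADME assay on the whole organism (strain Sprague-Dawley) for metabolic stability, with Rattus norvegicus as the target, at a dose of 2 mg/kg by the intravenous route (on this read-out higher numbers stand for a longer-lived compound and lower numbers for a shorter-lived compound), compound 1 (`N#Cc1cc(Cl)cc(Oc2cc(OCc3noc4nc(-n5ccnc5)ccc34)ccc2Cl)c1`) gives 1.7 h and compound 2 (`N#Cc1cc(Cl)cc(Oc2cc(OCc3noc4nc(N)ccc34)ccc2Cl)c1`) gives 5.8 h as the higher of the only two numbers so far. Among the compounds with values here, the single measured step is a 3.4-fold higher number from compound 1 to compound 2 (0.53 log units; beyond the scatter) with amino in place of 1H-imidazol-1-yl on an aromatic carbon. Compound 3 (`CNc1ccc2c(COc3ccc(Cl)c(Oc4cc(Cl)cc(C#N)c4)c3)noc2n1`) has not yet been measured. It differs from compound 2 by methyl in place of hydrogen on a nitrogen on an aromatic ring and so reads as amino to methylamino. The measured step concerns the same place in the molecule but exchanges a different pair of groups, so it bears on the new change only loosely. Within the data shown here, no measured pair shows what methyl in place of hydrogen on that nitrogen does. A change smaller than a 3.4-fold higher number from compound 1 to compound 2 (0.53 log units; beyond the scatter) is therefore expected, leaning slightly downward and probably not beyond the scatter. The expected move is a 1.3-fold lower number from compound 2 to compound 3 (0.11 log units; within the scatter) on this estimate. In this assay compound 3 is estimated at 4.5 h with an expected range from 2.2 h to 9 h for a single measurement.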

Compound 3, half-life: 2 h
Compound 3: middle estimate off by 2.3-fold (0.35 log units), on the high side; measured number below the stated range.
By their numbers in this assay, from the lowest: compounds 1 and 3 (each within the scatter of the next); then compound 2.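

In this assay, the earlier pair showed that exchanging one group for another on this aromatic carbon could change the half-life, but it involved a large replacement. The new result shows that a far smaller change is enough: adding a single methyl to the nitrogen on an aromatic ring gives a 2.9-fold lower number from compound 2 to compound 3 (0.46 log units; beyond the scatter), so amino and methylamino cannot be treated as interchangeable here. Alongside this, a 1.2-fold higher number from compound 1 to compound 3 (0.07 log units; within the scatter) puts methylamino level with 1H-imidazol-1-yl, leaving amino as the only one of the three groups that stands apart, with the longer-lived compound. Nothing available here gives a reason for this difference.

The compounds shown leave open whether a bulkier or further substituted nitrogen group, such as ethylamino, dimethylamino or acetamido, would stay level with methylamino or take the half-life elsewhere. They also leave open whether a different group with a free hydrogen on the nitrogen, such as hydroxyamino, would share the longer half-life of the amino compound.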